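Chloro to piperidin-1-yl on the shared core

The source may hold more compounds than are shown below. What is called first, only, known or untested is meant among the compounds shown, and "the series" means these compounds.

The series is read in an in vitro assay on HEK-tsA201 cells for antagonist activity at Neuronal acetylcholine receptor; alpha4/beta2 (Homo sapiens), read by fluorescence and calcium flux; on this read-out higher numbers stand for weaker inhibition and lower numbers for stronger inhibition. Compound 1 `CCOc1ccc(C(=O)Nc2cc(C)cc(C)n2)cc1` gives 17100 nM in this assay, and compound 3 `CCCOc1ccc(C(=O)Nc2cnccn2)cc1` gives 23200 nM; these two values lie within the usual scatter of each other. Compound 2 `CCCOc1ccc(C(=O)Nc2cccc(Cl)n2)cc1` is reported only as a limit, > 100000 nM. This is the limit of > 100000 nM in this assay, at which 1 of the 3 values shown sits, so for compound 2 no number is known, only that it sits at the edge of what the assay can report. Compound 4 `CCCOc1ccc(C(=O)Nc2cccc(N3CCCCC3)n2)cc1` has not yet been measured. It differs from compound 2 by piperidin-1-yl in place of chloro on an aromatic carbon. For the measured compounds named here, no pair of measured compounds differs in one place, so a step of this kind has not been seen, and the expectation rests on the whole set being weak throughout. The expected step from compound 2 to compound 4 in this assay is an at least 2.0-fold lower number from compound 2 to compound 4 (0.30 log units; that floor lies within the scatter), read as a move back into the range where a number is reported. Compound 4 is estimated at 50000 nM, expected to fall between 12000 nM and 200000 nM, with a real chance that only a limit is again reported.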

Compound 4, half-maximal inhibitory concentration: > 100000 nM
Compound 4: no number, only a limit (the forecaster's own chance of this, stated with the estimate: 40%); middle value at least 2.0-fold (0.30 log units) from the limit.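

No step from compound 2 to compound 4 can be read, because both compounds are reported only as limits, not numbers: the limit of > 100000 nM in this assay, at which 2 of the 4 values shown sit.

The compounds shown leave open whether piperidin-1-yl in place of chloro on an aromatic carbon changes inhibition at all, and in which direction.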